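The source may report more compounds than this note shows. Statements on the series, on what has been measured and on what is new or still open speak of the compounds shown alone.

Compound 1 `C/N=C(/NC#N)NCCCn1nc(-c2ccccc2)ccc1=O` in a functional assay on the whole organism (stomach) with Rattus norvegicus as the target; on this read-out lower numbers stand for an effect already at smaller amounts and higher numbers for an effect only at larger amounts of compound: > 100 mg/kg.
Compound 2 `CC(C)(C)/N=C(\S)NCCCCn1nc(-c2ccccc2)ccc1=O` in this assay: > 100 mg/kg.

Both entries are limits of the assay, not numbers. Compound 2 thus sits at the limit of > 100 mg/kg in this assay, at which 2 of the 2 values shown sit, and cannot be placed more closely. Compound 3 `C=CCNC(=S)NCCCCn1nc(-c2ccccc2)ccc1=O` differs from compound 2 by a group of 6 heavy atoms (4 carbon, 1 nitrogen, 1 sulfur; no ring) in place of a group of 7 heavy atoms (5 carbon, 1 nitrogen, 1 sulfur; no ring), on an amine nitrogen. Within the data shown here, no step between measured compounds is recorded, so the size of this change has no precedent here; no movement beyond the scatter is expected in this assay, and a limit again seems the most likely outcome. Compound 3 is therefore estimated at 150 mg/kg, within 50 mg/kg to 500 mg/kg, an expected step that the limit leaves unreadable from compound 2 to compound 3.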

Compound 3, dose for half-maximal effect: > 100 mg/kg
Compound 3: no number, only a limit (the forecaster's own chance of this, stated with the estimate: 80%); the middle value lies beyond the limit too.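

Among these compounds, compound 1, compound 2 and compound 3 all rest on a limit, not a number, so no step among them can be read: the limit of > 100 mg/kg in this assay, at which 3 of the 3 values shown sit. The compounds shown leave open how far each lies beyond that limit in this assay.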